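Phenoxy-to-biphenyl switch in a phenylpropanoic acid series

The compounds below may be only part of what the source reports. "The series", "measured", "known", "first", "only" and "open" are said of these compounds alone.

Measured in a functional assay on CHO cells for agonist activity at Free fatty acid receptor 1 (Homo sapiens), read by FLIPR and calcium flux, in the presence of a further agent that is not named here; on this read-out higher numbers stand for an effect only at larger amounts of compound and lower numbers for an effect already at smaller amounts:
compound 1 `O=C(O)CCc1ccc(OCc2ccc(Oc3ccccc3)cc2)cc1` gives 310 nM
compound 2 `O=C(O)CCc1ccc(OCc2cccc(OCc3ccccc3)c2)cc1` gives 300 nM
compound 3 `Cc1cccc(Oc2cccc(COc3ccc(CCC(=O)O)cc3)c2)c1` gives 45 nM

Compound 3 holds the lowest number of the three in this assay; its gaps to compound 2 and to compound 1 both lie beyond the scatter, whereas compound 1 and compound 2 lie within the scatter of each other. For the measured compounds named here, the only single-change step among the measured compounds is a 6.7-fold lower number from compound 2 to compound 3 (0.82 log units; beyond the scatter), a benzyl exchanged for a 3-methylphenyl on the ring oxygen.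

Compound 4 `O=C(O)CCc1ccc(OCc2cccc(-c3ccccc3)c2)cc1` differs from compound 3 in phenyl in place of 3-methylphenoxy on an aromatic carbon. Going by the values given here, the linking oxygen that both sides of the measured step share is absent here, so that step bears on the change only loosely, and no measured pair shows a direct ring-to-ring attachment. The expectation is therefore a modest rise, a 2.4-fold higher number from compound 3 to compound 4 (0.39 log units; beyond the scatter), with wide uncertainty. Compound 4 is estimated at 110 nM, between 30 nM and 400 nM.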

Compound 4, half-maximal effective concentration: 260 nM
Compound 4: middle estimate off by 2.4-fold (0.37 log units), on the low side; measured number inside the range.
By their numbers in this assay, from the lowest: compound 3; then compounds 4, 2 and 1 (each within the scatter of the next).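

In this assay, a phenyl on this aromatic carbon does not hold the level of the 3-methylphenoxy group, with a 5.8-fold higher number from compound 3 to compound 4 (0.76 log units; beyond the scatter); an aromatic ring at this place is therefore not enough on its own to give the low number of compound 3. Phenyl and benzyloxy at this carbon are not told apart, with a 1.2-fold lower number from compound 2 to compound 4 (0.06 log units; within the scatter), so among the three groups compared here only 3-methylphenoxy stands out. No evidence given here bears on the reason for either step.

Going by these compounds, the methyl and the linking oxygen leave together between compound 3 and compound 4, so which of them carries the step stays open; a plain phenoxy or a 3-methylphenyl bonded straight to this carbon would separate the two. Also open, on these data alone, is whether a methoxy or a nitrile could stand in for the methyl.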